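From Compound 3 to a Trihydroxy Ring Substituent

The source may report more compounds than this note shows. Statements on the series, on what has been measured and on what is new or still open speak of the compounds shown alone.

Going by the values given here, in a functional assay on MCF7 cells (Homo sapiens) for cytotoxicity, read by MTT assay, with a stated time of 72 h (a lower number here means a stronger inhibitor, a higher number a weaker inhibitor), three compounds with a shared core have numbers so far. Compound 1 `O=C1c2c[n+]([O-])c3ccccc3c2C(=O)c2c1c1ccccc1n2Cc1cn(CC(O)CO)nn1` gives 1110 nM and compound 2 `CC1(C)O[C@@H](CO)[C@H](Cn2cc(Cn3c4c(c5ccccc53)C(=O)c3c[n+]([O-])c5ccccc5c3C4=O)nn2)O1` gives 690 nM while compound 3 `CC1(C)OC[C@H](Cn2cc(Cn3c4c(c5ccccc53)C(=O)c3c[n+]([O-])c5ccccc5c3C4=O)nn2)O1` gives 530 nM on the same scale. Among the compounds with values here, the step of a 1.3-fold lower number from compound 2 to compound 3 (0.11 log units; within the scatter) leaves compound 3 level with compound 2, and only the step of a 2.1-fold lower number from compound 1 to compound 3 (0.32 log units; beyond the scatter) separates compound 3 from another compound.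

Compound 4 `O=C1c2c[n+]([O-])c3ccccc3c2C(=O)c2c1c1ccccc1n2Cc1cn([C@@H]2O[C@H](CO)[C@@H](O)[C@H](O)[C@H]2O)nn1` has not been measured yet. It differs from compound 3 as follows: 3,4,5-trihydroxy-6-(hydroxymethyl)oxan-2-yl in place of (2,2-dimethyl-1,3-dioxolan-4-yl)methyl on an aromatic nitrogen on an aromatic nitrogen of a five-membered aromatic ring with 3 nitrogen.

The nearest guide is compound 1, the other compound whose side chain ends in free hydroxyl groups, and it gives the higher number in the step of a 2.1-fold lower number from compound 1 to compound 3 (0.32 log units; beyond the scatter) for a modest gap. Compound 2 goes against any simple count of hydroxyl groups, since it keeps one and the step of a 1.6-fold lower number from compound 1 to compound 2 (0.21 log units; within the scatter) stays small. Within the data shown here, no measured compound carries the six-membered ring, so this guide is loose.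

The step expected here is a 2.6-fold higher number from compound 3 to compound 4 (0.42 log units; beyond the scatter) toward the higher side. For compound 4 the estimate is 1400 nM with an expected range from 500 nM to 4000 nM as its likely span.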

Compound 4, half-maximal inhibitory concentration: 590 nM
The estimate for compound 4 lay 2.4-fold (0.38 log units) above the measured number; low and high end bracket the measured number.
By their numbers in this assay, from the lowest: compounds 3, 4, 2 and 1 (each within the scatter of the next, the first and the last beyond it).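

In this assay, putting 3,4,5-trihydroxy-6-(hydroxymethyl)oxan-2-yl in place of (2,2-dimethyl-1,3-dioxolan-4-yl)methyl on the aromatic nitrogen gives a 1.1-fold higher number from compound 3 to compound 4 (0.05 log units; within the scatter), so this position tolerates a larger group with a six-membered ring and hydrogen-bond donors, where the group it replaces has none. Compound 4 is also level with the other two, with a 1.2-fold lower number from compound 2 to compound 4 (0.07 log units; within the scatter) and a 1.9-fold lower number from compound 1 to compound 4 (0.27 log units; within the scatter), and since it carries free hydroxyl groups yet stands level with compound 3, it goes against the idea, suggested by compound 1 alone, that free hydroxyl groups on this side chain go with a higher number. Nothing available here explains why such different groups give such similar numbers.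

Every group shown at this nitrogen contains only carbon and oxygen beyond its hydrogens, so it remains open whether one bearing an amine or a carboxylic acid would also stay level with compound 3. On these data alone, it is also open whether the six-membered ring matters in itself, which a plain oxan-2-yl group without hydroxyl groups could test.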